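The compounds below may be only part of what the source reports. "The series", "measured", "known", "first", "only" and "open" are said of these compounds alone.

- Compound 1 `CC(C)CNc1nc(N)nc2c1ncn2/C=C1/CC1(CO)CO` gives "not determined" (no result reported)
- Compound 2 `CC(C)Sc1nc(N)nc2c1ncn2/C=C1/CC1(CO)CO` gives > 20000 nM

Both compounds share one core, and the test followed here is an ADME assay on MOLT-3 cells (Homo sapiens) for cytotoxicity, with a stated time of 7 days (on this read-out higher numbers stand for lower toxicity in this test and lower numbers for higher toxicity in this test), for both. In this assay compound 2 gives > 20000 nM as a limit of the assay and not a number. Compound 1 has no reported result, so it offers nothing to compare with.

Compound 3 `CCCCNc1nc(N)nc2c1ncn2/C=C1/CC1(CO)CO` keeps the shared core and carries butylamino in place of isopropylsulfanyl on an aromatic carbon, a change counted as butylamino in place of isopropylsulfanyl on an aromatic carbon in full. Going by the values given here, no measured pair shows what such an exchange does in this assay on these compounds. Among the compounds with values here, the only anchor is compound 2 at > 20000 nM as a limit, so the expectation is no shift beyond the usual scatter in either direction. Another limit in place of a number would be no surprise. The expected change, a number no higher from compound 2 to compound 3 (the limit leaves the size open), is therefore a small one. For compound 3 the estimated value is 20000 nM, with an expected range from 6000 nM to 50000 nM in this test.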

Compound 3, half-maximal cytotoxic concentration: > 20000 nM
Compound 3: a limit, no number; the forecaster's own chance of this, stated with the estimate: 60%; the middle value lies on the limit itself.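

Going by these compounds alone, compound 2 and compound 3 both end at a limit of the assay and not at a number, so no step between them can be read in this assay. The compounds shown leave open whether butylamino in place of isopropylsulfanyl on an aromatic carbon changes the half-maximal cytotoxic concentration at all, and in which direction.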